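Adding a fluoro to the anilino ring of compound 3

The compounds below may be only part of what the source reports. "The series", "measured", "known", "first", "only" and "open" are said of these compounds alone.

Of the compounds shown here, three built on one shared core have been tested in a functional assay on NCI-H1975 cells (Homo sapiens) for inhibition, read by MTT assay, with a stated time of 72 h; on this read-out lower numbers stand for stronger inhibition and higher numbers for weaker inhibition. Compound 1 `O=C(CSc1nc(Nc2ccccc2)c2ccccc2n1)Nc1ccccc1Cl` gives 9610 nM. Compound 2 `O=C(CSc1nc(Nc2ccccc2)c2ccccc2n1)Nc1cccc(F)c1` gives 6790 nM, and compound 3 `C=CC(=O)Nc1cccc(NC(=O)CSc2nc(Nc3ccccc3)c3ccccc3n2)c1` gives 8120 nM. Compound 3 stands second highest of the three numbers, but all three sit close together: a 1.2-fold lower number from compound 1 to compound 3 (0.07 log units; within the scatter), and a 1.2-fold higher number from compound 2 to compound 3 (0.08 log units; within the scatter), so nothing separates them beyond the usual scatter.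

Compound 4 `C=CC(=O)Nc1cccc(NC(=O)CSc2nc(Nc3ccccc3F)c3ccccc3n2)c1` differs from compound 3 in one place: fluoro in place of hydrogen on an aromatic carbon. For the measured compounds named here, no measured step touches this anilino ring; the three known steps all change the aryl on the amide-type nitrogen. The nearest parallel is a 1.4-fold lower number from compound 1 to compound 2 (0.15 log units; within the scatter), where one halogen replaced another on that other ring without a step beyond the scatter, and a 1.2-fold higher number from compound 2 to compound 3 (0.08 log units; within the scatter) shows the same tolerance. Going by the values given here, with no step on the anilino ring measured, the expectation rests on this general insensitivity, and the step from compound 3 to compound 4 is expected to be a 1.0-fold lower number from compound 3 to compound 4 (0.01 log units; within the scatter), none beyond the scatter. Compound 4 is therefore estimated at 8000 nM in this assay, with a range from 3000 nM to 20000 nM.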

Compound 4, half-maximal inhibitory concentration: 6580 nM
Estimate against measurement, compound 4: 1.2-fold (0.08 log units) above; measured number inside the range.
By their numbers in this assay, from the lowest: compounds 4, 2, 3 and 1 (each within the scatter of the next).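

In this assay, for the compounds shown here, the change from phenyl to 2-fluorophenyl gives a 1.2-fold lower number from compound 3 to compound 4 (0.09 log units; within the scatter) and is the first reading on the anilino ring, which no earlier step touched. It shows that a fluoro on an aromatic carbon of this ring, ortho to a large group, leaves the number within the scatter, so this ring now joins the aryl on the amide-type nitrogen as a place where a single change has not moved the result measurably. Nothing measured here bears on why the fluoro changes so little.

This is one small atom at one place on one ring, so it cannot show how the anilino ring responds to other groups: a methoxy, an amine, a carboxylic acid or a larger trifluoromethyl there could behave quite differently. It also leaves open whether combining a substituted anilino ring with a different aryl on the amide-type nitrogen, such as a 3-fluorophenyl in place of the 3-((vinylcarbonyl)amino)phenyl, would take the number beyond the scatter.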